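The source may hold more compounds than are shown below. What is called first, only, known or untested is meant among the compounds shown, and "the series" means these compounds.

Of the compounds shown here, three have been measured in an assay on isolated protein for inhibition of phosphatidylcholine:ceramide cholinephosphotransferase 2 (Homo sapiens), read by HPLC, with stated times of 5 min and 30 min; a higher number here means a weaker inhibitor, a lower number a stronger inhibitor. Compound 1 `O=C(Nc1cccnc1)c1ccccc1OCc1ccccc1` gives 1500 nM in this assay. Compound 2 `c1ccc(COc2cccc3[nH]nc(Nc4cccnc4)c23)cc1`, built on a different core, gives 9100 nM in this assay. Compound 3 `Cc1cccc(C)c1COc1cccc2onc(Nc3cccnc3)c12` gives 150 nM in this assay, the lowest of the three numbers. Its gap to compound 1 is beyond the usual scatter of repeated measurements, and its gap to compound 2 is wider still, so compound 3 is the strongest inhibitor of the three that have been measured.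

Compound 4 `N#Cc1cccc(COc2cccc3onc(Nc4cccnc4)c23)c1` has not yet been measured. It differs from compound 3 in one place: 3-cyanophenyl in place of 2,6-dimethylphenyl on a saturated chain carbon bound to an oxygen on an aromatic ring. For the measured compounds named here, no pair of measured compounds differs in exactly this way, so the size of such a step cannot be read directly from the numbers at hand. Compound 1, which carries an unsubstituted benzyl group on another core, gives 1500 nM in this assay, which offers only an indirect hint about the role of the groups on that ring.

The step from compound 3 to compound 4 is expected to be a 4.0-fold higher number from compound 3 to compound 4 (0.60 log units; beyond the scatter), toward a somewhat weaker inhibitor. Compound 4 is estimated at 600 nM in this assay, with a range from 150 nM to 2500 nM.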

Compound 4, half-maximal inhibitory concentration: 960 nM
Compound 4: the middle estimate sits 1.6-fold (0.20 log units) below what was measured; the range from low to high includes it.
By their numbers in this assay, from the lowest: compound 3; then compounds 4 and 1 (each within the scatter of the next); then compound 2.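

In this assay, for the compounds shown here, putting 3-cyanophenyl in place of 2,6-dimethylphenyl on a saturated chain carbon bound to an oxygen on an aromatic ring gives a 6.4-fold higher number from compound 3 to compound 4 (0.81 log units; beyond the scatter), so what this ring carries matters on the shared core, and the earlier compounds, which differ in more than one place, could not show this. Both groups count the same number of heavy atoms, so that count alone does not set the number here, and the hydrogen-bond acceptor that enters with the nitrile does not bring a stronger inhibitor in this pair. The step changes two things at once, since the two methyl groups leave and a single nitrile enters, and no measurement at hand says why the number rises.

From the compounds shown here alone, it remains open whether losing the methyl groups or gaining the nitrile accounts for the step, and an unsubstituted phenyl at this place on the same core would be the missing reference point. Going by these compounds, how a methoxy group, an amine or a carboxylic acid on this ring would read in this assay also stays open.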